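Hydroxyphenyl placement and inhibition in HCT-15 cells

The source may report more compounds than this note shows. Statements on the series, on what has been measured and on what is new or still open speak of the compounds shown alone.

Compound 1 `Oc1ccc(-c2cc(-c3cccc(C(F)(F)F)c3)cc(-c3cccc(O)c3)n2)cc1` and compound 2 `Oc1ccc(-c2cc(-c3cccc(C(F)(F)F)c3)cc(-c3ccc(O)cc3)n2)cc1` differ by 4-hydroxyphenyl in place of 3-hydroxyphenyl on an aromatic carbon. In a functional assay on HCT-15 cells (Homo sapiens) for inhibition (on this read-out higher numbers stand for weaker inhibition and lower numbers for stronger inhibition), compound 1 gives 9540 nM. For compound 2 the assay reports only a limit, > 50000 nM. The step, an at least 5.2-fold higher number from compound 1 to compound 2 (0.71 log units; beyond the scatter), runs into (the limit of > 50000 nM in this assay, at which 1 of the 3 values shown sits).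

Compound 3 `Oc1ccc(-c2cc(-c3ccccc3OC(F)(F)F)cc(-c3cccc(O)c3)n2)cc1` carries a different core; how it differs from the core of compound 1 is not broken down here. In this assay compound 3 gives 2310 nM. Compound 4 `Oc1ccc(-c2cc(-c3ccccc3OC(F)(F)F)cc(-c3ccc(O)cc3)n2)cc1` differs from compound 3 by 4-hydroxyphenyl in place of 3-hydroxyphenyl on an aromatic carbon. This is the same kind of change as from compound 1 to compound 2, though the surroundings differ: in compound 1 the site is meta to a 3-(trifluoromethyl)phenyl group, in compound 3 it is meta to a large group.

For compound 4 the expected step is a 6.1-fold higher number from compound 3 to compound 4 (0.78 log units; beyond the scatter), resting on an at least 5.2-fold higher number from compound 1 to compound 2 (0.71 log units; beyond the scatter). The estimate for compound 4 in this assay is 14000 nM, expected to fall from 5000 nM to 45000 nM, with a limit possible.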

Compound 4, half-maximal inhibitory concentration: 7760 nM
Beside the measured number, compound 4's estimate is 1.8-fold (0.26 log units) above it, within the range that was stated.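

In this assay, 4-hydroxyphenyl in place of 3-hydroxyphenyl again raises the number, with a 3.4-fold higher number from compound 3 to compound 4 (0.53 log units; beyond the scatter), so the direction of the change carries over between the two cores shown. Two cores do not show that it would hold on any other core in the series. Whether the size of the step carries over stays unsettled: the same change on two cores in this assay, an at least 5.2-fold higher number (0.71 log units; beyond the scatter) from compound 1 to compound 2 and a 3.4-fold higher number (0.53 log units; beyond the scatter) from compound 3 to compound 4; the limit leaves it open whether they differ

Still open, as far as these compounds go, is how an amine or a carboxylic acid in place of the hydroxyl on this ring would read in this assay. Also open, from the compounds shown here alone, is whether the same direction appears on a core carrying neither the 3-(trifluoromethyl)phenyl group of compound 1 nor the large group of compound 3.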